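Trimming a methoxy group from a diarylpropane scaffold

The compounds below may be only part of what the source reports. "The series", "measured", "known", "first", "only" and "open" are said of these compounds alone.

Measured compounds:
compound 1 `COc1ccc(CCCc2ccc(OC)cc2OC)c(O)c1`, 97.7%
compound 2 `COc1ccc(CCCc2ccc(OC)c(OC)c2OC)c(O)c1`, 95.5%
compound 3 `COc1ccc(C(=O)CCc2ccc(OC)c(OC)c2)c(O)c1`, 89%

All three were tested in an ADME assay on RAW264.7 cells (Mus musculus) for cytotoxicity, read by MTT assay, with a stated time of 24 h, tested at 2.5 ug/mL; on this read-out lower numbers stand for a stronger effect and higher numbers for a weaker effect at the one concentration tested. Compound 1 gives 97.7% and compound 2 gives 95.5%, and compound 3 gives 89%. The change from compound 2 to compound 1 is hydrogen in place of methoxy on an aromatic carbon; it made a step of a number 2.2 percentage points higher from compound 2 to compound 1 (within the scatter). Compound 4 `COc1ccc(CCC(=O)c2ccc(OC)cc2O)cc1` is not yet measured; it comes from compound 3 by hydrogen in place of methoxy on an aromatic carbon. This is the same kind of change, though the place differs: in compound 2 the carbon is ortho to two methoxy groups, in compound 3 ortho to a methoxy group. How the cores of compound 3 and compound 2 differ is not broken down here. Because the earlier step of a number 2.2 percentage points higher from compound 2 to compound 1 (within the scatter) stayed within the scatter, compound 4 is expected to show a step of a number 3 percentage points higher from compound 3 to compound 4 (within the scatter). Compound 4 is therefore estimated at 92%, within 82% to 100%.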

Compound 4, a percentage reported as activity, at one concentration (the size of the read-out at that concentration, not a potency): 94.5%
The estimate for compound 4 lay 2.5 percentage points below the measured number; the measured number falls inside the stated range.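

In this assay, replacing methoxy with hydrogen on a second core gave a step of a number 5.5 percentage points higher from compound 3 to compound 4 (within the scatter). The two steps agree as closely as this read-out can tell, so the change carried from one core to the other without a detectable difference: the same change on two cores in this assay, a number 2.2 percentage points higher (within the scatter) from compound 2 to compound 1 and a number 5.5 percentage points higher (within the scatter) from compound 3 to compound 4, 3.3 percentage points apart, within the scatter of two such steps This does not show that the change has no effect under other conditions, and two pairs tested at a single concentration cannot establish a rule for other cores in the series.

The compounds shown leave open what would happen if the methoxy group gave way to something other than hydrogen, such as an amine or a carboxylic acid. They also leave open what a longer chain linking the aromatic rings would do.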